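A few compounds are considered here, and "the series" means these few. Any claim that something is new, unique, unknown or untested is made for them only; others in the source may bear on it.

Measured compounds in the series:
- compound 1 `CC(=O)NCc1cccc(Cn2nc(NS(=O)(=O)c3ccc(Cl)s3)c3c(CO)cccc32)c1` — 6.31 nM
- compound 2 `COc1cccc2c1c(NS(=O)(=O)c1ccc(Cl)s1)nn2Cc1cccc(CNC(=O)C2COC2)c1` — 20 nM

The read-out throughout is a functional assay on CHO cells for antagonist activity at C-C chemokine receptor type 4 (Homo sapiens), read by GTPgammaS binding; a lower number here means a stronger inhibitor, a higher number a weaker inhibitor. Of the two numbers to hand, compound 2 gives the higher one with 20 nM; the nearest point is compound 1, whose value lies lower by a margin beyond the usual scatter. Among the measured compounds shown here, compounds 1 and 2 differ in more than one place, so their gap cannot be assigned to any single change and no step between measured compounds is available.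

Compound 3 `COc1cccc2c1c(NS(=O)(=O)c1ccc(Cl)s1)nn2Cc1cccc(CNC(=O)[C@@H]2CCCCN2)c1` is built from compound 2 by one change: piperidin-2-yl in place of oxetan-3-yl on a carbonyl carbon. For the measured compounds named here, nothing among the measured compounds reports on this particular exchange at the amide carbonyl, so the expectation rests on compound 2 alone. Going by the values given here, with no precedent for either direction, the expected step of a 1.3-fold lower number from compound 2 to compound 3 (0.10 log units; within the scatter) is taken as essentially flat, no larger than the scatter, with the range left wide to cover a moderate move either way. On that basis compound 3 is estimated at 16 nM in this assay, with a range from 5 nM to 50 nM.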

Compound 3, half-maximal inhibitory concentration: 15.9 nM
Estimate against measurement, compound 3: 1.0-fold (0.00 log units) above; measured number inside the range.
By their numbers in this assay, from the lowest: compound 1; then compounds 3 and 2 (each within the scatter of the next).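

In this assay, among the compounds shown here, the exchange of oxetan-3-yl for piperidin-2-yl on a carbonyl carbon gives a 1.3-fold lower number from compound 2 to compound 3 (0.10 log units; within the scatter), so this is the first reading at this place, and it shows no change beyond the scatter. A six-membered non-aromatic ring with a nitrogen, a hydrogen-bond donor and a defined stereocentre thus stands where a four-membered non-aromatic ring with an oxygen stood, and the two compounds remain level in this one comparison. No measured property bears on this result, and the step itself gives no explanation for it.

Still open, from the compounds shown here alone, is whether this level reading holds for other groups on the same carbonyl carbon, such as the opposite stereoisomer of piperidin-2-yl, piperidin-4-yl, an open-chain dimethylaminomethyl group or a carboxylic acid. Also open, going by these compounds, is which difference separates compound 1 at 6.31 nM from compound 3 at 15.9 nM, since these two compounds differ in more than one place and no single change can be read from their values.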